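This account rests on a few compounds, and the source may have more. Where it says the series, first, only, none or still open, it means among the compounds named here.

Compound 1 `COc1cc(Cc2cnc(/N=C3\C(=O)N(CN4CCN(c5ccc(F)cc5)CC4)c4ccc(Cl)cc43)nc2N)cc(OC)c1OC` opens this comparison. In an ADME assay on CCRF-CEM cells (Homo sapiens) for cytotoxicity, read by MTT assay, with a stated time of 5 days (on this read-out higher numbers stand for lower toxicity in this test and lower numbers for higher toxicity in this test), compound 1 gives 71 ug/mL, the only plain number among the two results shown. Compound 2 `COc1cc(Cc2cnc(/N=C3\C(=O)N(CN4CCCCC4C)c4ccc(Cl)cc43)nc2N)cc(OC)c1OC` shares the same core. In this assay compound 2 reaches only a limit, recorded as > 83.8 ug/mL. Of the two results, one therefore sits at the limit of > 83.8 ug/mL in this assay, at which 1 of the 2 values shown sits. Compound 3 `COc1cc(Cc2cnc(/N=C3\C(=O)N(CN4CCN(c5ccc(Cl)cc5)CC4)c4ccc(Cl)cc43)nc2N)cc(OC)c1OC` is the compound still to be measured; against compound 1 its change is chloro in place of fluoro on an aromatic carbon. For the measured compounds named here, no measured pair shows the effect of this exchange, so a step of a 1.0-fold lower number from compound 1 to compound 3 (0.01 log units; within the scatter) is expected, no larger than the usual scatter. Compound 3 is accordingly estimated at 70 ug/mL, between 35 ug/mL and 100 ug/mL.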

Compound 3, half-maximal cytotoxic concentration: 40.1 ug/mL
The estimate for compound 3 lay 1.7-fold (0.24 log units) above the measured number; the measured number falls inside the stated range.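

For the compounds shown here, this is the first measured exchange at this position: for 4-fluorophenyl to 4-chlorophenyl, this assay gives a 1.8-fold lower number from compound 1 to compound 3 (0.25 log units; within the scatter). A step of this size means that chloro and fluoro on this aromatic carbon cannot be told apart in this test. Compound 2 carries a different group on the shared core and remains a limit, so no step to it can be read: the limit of > 83.8 ug/mL in this assay, at which 1 of the 3 values shown sits.

Still open, on these data alone, is whether another group on this carbon, such as an amine or a carboxylic acid, would give a step beyond the scatter.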